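Sulfonyl aryl variation on the shared core

The source may report more compounds than this note shows. Statements on the series, on what has been measured and on what is new or still open speak of the compounds shown alone.

Compound 1 `CN1CCC(N(C)C(=O)C2CN(S(=O)(=O)c3ccc4ccccc4c3)c3ccccc32)CC1` and compound 2 `CN1CCC(N(C)C(=O)C2CN(S(=O)(=O)c3ccc(C(F)(F)F)cc3)c3ccccc32)CC1` share one core and differ only in the aryl group on the sulfonyl sulfur. In a functional assay on CHO cells for antagonist activity at 5-hydroxytryptamine receptor 6 (Homo sapiens), read by FLIPR (on this read-out higher numbers stand for weaker inhibition and lower numbers for stronger inhibition), compound 1 gives 25.1 nM, and compound 2 gives 25.1 nM. The step of no change at the digits printed from compound 1 to compound 2 (within the scatter) puts 4-(trifluoromethyl)phenyl in place of naphthalen-2-yl without moving the read-out beyond the scatter, so compound 2 stands level with compound 1 on the numbers in hand. Compound 3 `CN1CCC(N(C)C(=O)C2CN(S(=O)(=O)c3ccc(OC(F)(F)F)cc3)c3ccccc32)CC1` is the next to be measured; it differs from compound 2 by trifluoromethoxy in place of trifluoromethyl on an aromatic carbon, para to a large group. For the measured compounds named here, no measured step bears directly on this exchange; the only step available, no change at the digits printed from compound 1 to compound 2 (within the scatter), stayed within the scatter despite a larger change of the aryl group. Compound 3 is therefore expected to stay within the scatter of compound 2, a step of a 1.0-fold lower number from compound 2 to compound 3 (0.00 log units; within the scatter). The estimate for compound 3 in this assay is 25 nM, with a range of 10 nM to 63 nM.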

Compound 3, inhibition constant: 20 nM
Estimate against measurement, compound 3: 1.3-fold (0.10 log units) above; measured number inside the range.
By their numbers in this assay, from the lowest: compounds 3, 1 and 2 (each within the scatter of the next).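

In this assay, the exchange of trifluoromethyl for trifluoromethoxy on an aromatic carbon, para to a large group, now has a direct reading: the result is a 1.3-fold lower number from compound 2 to compound 3 (0.10 log units; within the scatter) and so this single exchange at this position does not separate the two compounds. The wider change on the sulfonyl sulfur gives a 1.3-fold lower number from compound 1 to compound 3 (0.10 log units; within the scatter) and adds a third aryl group to the set that this read-out does not separate: naphthalen-2-yl, 4-(trifluoromethyl)phenyl and 4-(trifluoromethoxy)phenyl. No supporting data are available to explain this flat response.

On these data alone, whether an amine or a carboxylic acid on that aromatic carbon, or an unsubstituted phenyl on the sulfonyl sulfur, would move the number beyond the scatter remains open. As far as these compounds go, all three compounds share the rest of the core, so the response to changes elsewhere also remains open.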